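The source may report more compounds than this note shows. Statements on the series, on what has been measured and on what is new or still open speak of the compounds shown alone.

Of the compounds shown here, three built on one shared core have been measured in an assay on HEK293 cells for binding affinity to Neuronal acetylcholine receptor; alpha4/beta2 (Homo sapiens); a higher number here means a weaker inhibitor, a lower number a stronger inhibitor. Compound 1 `N#Cc1ccc2c(c1)C1CNCC2C1` gives 0.5 nM, compound 2 `Fc1ccc2c(c1)C1CNCC2C1` gives 1.1 nM, and compound 3 `O=S(=O)(c1ccc2c(c1)C1CNCC2C1)N1CC1` gives 2 nM. Compound 3 therefore carries the highest of the three numbers: a 1.8-fold higher number from compound 2 to compound 3 (0.26 log units; within the scatter) lies within the scatter, whereas a 4.0-fold higher number from compound 1 to compound 3 (0.60 log units; beyond the scatter) lies beyond it.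

Compound 4 `Cc1ccc2c(c1)C1CNCC2C1` has not yet been measured. It differs from compound 3 in a single place: one carbon atom in place of a group of 6 heavy atoms (2 carbon, 1 nitrogen, 2 oxygen, 1 sulfur; one three-membered non-aromatic ring with 1 hetero atom), on an aromatic carbon. The group that leaves sits on an aromatic carbon of a six-membered aromatic ring of carbon only, part of a fused or bridged system of three rings.

For the measured compounds named here, two measured steps bear on this change. Each of them also exchanges the same large group against a small one on the same carbon. a 4.0-fold higher number from compound 1 to compound 3 (0.60 log units; beyond the scatter) was modest and beyond the scatter, while a 1.8-fold higher number from compound 2 to compound 3 (0.26 log units; within the scatter) stayed within it. Read in reverse, putting a small group in place of the large one has tended to lower the number, though with one fluorine atom it did so only within the scatter. A methyl is small like a fluorine, so the step of a 2.0-fold lower number from compound 3 to compound 4 (0.30 log units; within the scatter) is expected to be small, toward a lower number, and may stay within the scatter. Compound 4 is therefore estimated at 1 nM, with a range from 0.4 nM to 2.5 nM.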

Compound 4, inhibition constant: 1.6 nM
Beside the measured number, compound 4's estimate is 1.6-fold (0.20 log units) below it, and the stated range covers the measured number.
By their numbers in this assay, from the lowest: compound 1; then compounds 2, 4 and 3 (each within the scatter of the next).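

With methyl on this aromatic carbon, a 1.3-fold lower number from compound 3 to compound 4 (0.10 log units; within the scatter) and a 1.5-fold higher number from compound 2 to compound 4 (0.16 log units; within the scatter) both stay within the scatter, so the methyl compound cannot be told apart from either the fluoro compound or the compound with the large group holding the three-membered ring. Heavy-atom count therefore gives no order among these three groups, since one carbon atom, one fluorine atom and a group of 6 heavy atoms all sit within the scatter of the next, while a 3.2-fold higher number from compound 1 to compound 4 (0.51 log units; beyond the scatter) lies beyond it, as do the steps from compound 1 to the other two, leaving the nitrile as the only group here that stands apart. The data offer no measured explanation for why the nitrile separates from the other three groups.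

The compounds shown leave open whether an amine, a carboxylic acid or a longer chain such as propyl on this aromatic carbon would fall with compound 2, compound 3 and compound 4 or would join compound 1, at 0.5 nM. They also leave open whether the nitrile would keep its separation from methyl and fluoro on another carbon of the same aromatic ring.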